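Swapping a methylpyridine for an aminopyridine on the core

The source may hold more compounds than are shown below. What is called first, only, known or untested is meant among the compounds shown, and "the series" means these compounds.

Measured compounds:
compound 1 `Cc1ccccc1-c1cc(F)cc(-n2nnc(-c3ccccn3)n2)c1` — 120 nM in a functional assay for antagonist activity at metabotropic glutamate receptor 5 (Rattus norvegicus); on this read-out higher numbers stand for weaker inhibition and lower numbers for stronger inhibition
compound 2 `Cc1cccnc1-c1cc(F)cc(-n2nnc(-c3ccccn3)n2)c1` — 31 nM in this assay
compound 3 `Cc1cncc(-c2cc(F)cc(-n3nnc(-c4ccccn4)n3)c2)c1` — 499 nM in this assay

Among these three, compound 2 gives the lowest number in this assay; the nearest is compound 1 with a 3.9-fold lower number from compound 1 to compound 2 (0.59 log units; beyond the scatter), the furthest is compound 3 with a 16-fold higher number from compound 2 to compound 3 (1.21 log units; beyond the scatter). Compound 4 `Nc1ccncc1-c1cc(F)cc(-n2nnc(-c3ccccn3)n2)c1` has not been measured. Its change from compound 2 is 4-aminopyridin-3-yl in place of 3-methylpyridin-2-yl on an aromatic carbon. The relevant step is the one in this assay from compound 2 to compound 3, where a pyridin-3-yl group replaced the pyridin-2-yl group and the number rose markedly; compound 1 to compound 3 showed a 4.2-fold higher number from compound 1 to compound 3 (0.62 log units; beyond the scatter). Compound 4 also carries a pyridin-3-yl, so a rise beyond the scatter is expected, a 9.7-fold higher number from compound 2 to compound 4 (0.99 log units; beyond the scatter). For compound 4 the estimate is 300 nM, between 60 nM and 1500 nM.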

Compound 4, half-maximal inhibitory concentration: 108 nM
For compound 4 the middle estimate is 2.8-fold (0.44 log units) above the measured one; the measured number falls inside the stated range.
By their numbers in this assay, from the lowest: compound 2; then compounds 4 and 1 (each within the scatter of the next); then compound 3.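

In this assay, a pyridin-3-yl ring at this position need not give a number as high as that of compound 3, as 4-aminopyridin-3-yl in place of 5-methylpyridin-3-yl shows (a 4.6-fold lower number from compound 3 to compound 4 (0.66 log units; beyond the scatter)). Even so, 4-aminopyridin-3-yl does not match 3-methylpyridin-2-yl (a 3.5-fold higher number from compound 2 to compound 4 (0.54 log units; beyond the scatter)), and it is on a par with 2-methylphenyl (a 1.1-fold lower number from compound 1 to compound 4 (0.05 log units; within the scatter)). No measurement here accounts for these differences.

Still open, as far as these compounds go, is whether 3-aminopyridin-2-yl, an amine in place of the methyl of compound 2, would keep its low number. A methoxy group on that ring is equally untested among the compounds shown.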